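This account rests on a few compounds, and the source may have more. Where it says the series, first, only, none or still open, it means among the compounds named here.

Working notes on the series. Compound 1 `O=C(C1CC1)N1CCc2nc(C#Cc3ccccc3)sc2C1`, compound 2 `CC1CCCC(C(=O)N2CCc3nc(C#Cc4ccccc4)sc3C2)C1`, compound 3 `O=C(CC1CCOCC1)N1CCc2nc(C#Cc3ccccc3)sc2C1` and compound 4 `O=C(N1CCC(F)CC1)N1CCc2nc(C#Cc3ccccc3)sc2C1` share one core and differ only in the group on the carbonyl carbon. In an assay on HEK293 cells for negative allosteric modulation of metabotropic glutamate receptor 5 (Homo sapiens), read by FLIPR, with a stated time of 1 h (on this read-out lower numbers stand for stronger inhibition and higher numbers for weaker inhibition), compound 1 gives 290 nM. For compound 2 the read-out is a limit of the assay, > 10000 nM. For compound 3 the read-out is likewise a limit, > 10000 nM. Compound 3 therefore stands at the weak end of the numbers shown, at the same limit as one other value (the limit of > 10000 nM in this assay, at which 2 of the 3 values shown sit). The steps of an at least 34-fold higher number from compound 1 to compound 2 (1.53 log units; beyond the scatter) and an at least 34-fold higher number from compound 1 to compound 3 (1.53 log units; beyond the scatter) were both large, while the step that the two limits leave unreadable from compound 2 to compound 3 cannot be sized. The change now followed is 4-fluoropiperidin-1-yl in place of (oxan-4-yl)methyl on a carbonyl carbon. Going by the values given here, no measured step covers this exchange directly; the two readable steps only show that both replacements of cyclopropyl on the carbonyl carbon ended at the limit, so the step is expected to be small or not readable beyond the scatter, an at least 1.6-fold lower number from compound 3 to compound 4 (0.22 log units; that floor lies within the scatter). Compound 4 is expected to give 6000 nM, between 1500 nM and 20000 nM.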

Compound 4, half-maximal inhibitory concentration: > 10000 nM
Compound 4: no number, only a limit (the forecaster's own chance of this, stated with the estimate: 45%); at least 1.6-fold (0.22 log units) between middle value and limit.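

In this assay compound 4 also sits at a limit of the assay, > 10000 nM. Going by these compounds alone, a third group, now attached through its ring nitrogen, therefore ends at the limit, and with an at least 34-fold higher number from compound 1 to compound 4 (1.53 log units; beyond the scatter) being large, cyclopropyl remains the only group at this position with a number. The steps among compound 2, compound 3 and compound 4 cannot be read, so no order among their groups can be given, and the series stands as follows: the limit of > 10000 nM in this assay, at which 3 of the 4 values shown sit.

Open, as far as these compounds go, is how far a number persists away from cyclopropyl, which cyclobutyl or isopropyl on the carbonyl carbon would address. Also open, from the compounds shown here alone, is whether dimethylamino there gives a number, since compound 4 does not separate the attaching nitrogen from the six-membered ring.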